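The source may report more compounds than this note shows. Statements on the series, on what has been measured and on what is new or still open speak of the compounds shown alone.

Compound 1 `COc1ccc(/C=C/C(=O)c2ccccc2-c2ccc(F)cc2)cc1` was tested in a functional assay on MCF7 cells (Homo sapiens) for antiproliferative activity, read by sulforhodamine B assay, with a stated time of 48 h (a higher number here means a weaker inhibitor, a lower number a stronger inhibitor), where compound 1 gives 670 nM. Compound 2 `COc1ccc(/C=C/C(=O)c2ccccc2-c2ccc(F)nc2)cc1` differs from it in one place: 6-fluoropyridin-3-yl in place of 4-fluorophenyl on an aromatic carbon. In this assay compound 2 gives 2700 nM, so the change made a 4.0-fold higher number from compound 1 to compound 2 (0.61 log units; beyond the scatter). Compound 3 `O=C(/C=C/c1ccccc1-c1ccc(F)cc1)c1cccc(O)c1` is built on a different core, and the difference between the two cores is not broken down here. In this assay compound 3 gives 9300 nM, the highest of the three numbers. Compound 4 `O=C(/C=C/c1ccccc1-c1ccc(F)nc1)c1cccc(O)c1` has not yet been measured; it carries the same change that turns compound 1 into compound 2: 6-fluoropyridin-3-yl in place of 4-fluorophenyl on an aromatic carbon. The place of the change is described in the same words in both cases, so this is the same change, occurring twice among these compounds. Within the data shown here, the step it made before is the only guide available, and it comes from a single pair on a different core. From compound 3 to compound 4 a step of similar size is expected: a 3.2-fold higher number from compound 3 to compound 4 (0.51 log units; beyond the scatter). On that basis compound 4 is estimated at 30000 nM, with a plausible range from 10000 nM to 90000 nM.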

Compound 4, half-maximal inhibitory concentration: 12000 nM
Compound 4: middle estimate off by 2.5-fold (0.40 log units), on the high side, within the range that was stated.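

On the core of compound 3, in this assay, placing 6-fluoropyridin-3-yl where 4-fluorophenyl stood gave a 1.3-fold higher number from compound 3 to compound 4 (0.11 log units; within the scatter), so these two compounds cannot be told apart in this measurement. The change therefore did not carry its earlier effect across to this second core, and the two steps truly differ: the same change on two cores in this assay, a 4.0-fold higher number (0.61 log units; beyond the scatter) from compound 1 to compound 2 and a 1.3-fold higher number (0.11 log units; within the scatter) from compound 3 to compound 4, 3.1-fold (0.49 log units) apart, beyond the scatter of two such steps

Among these compounds, this shows that, in this series, the step seen on one core was not a reliable guide to the step on the other, but it rests on only two pairs and does not show which feature of the cores is responsible or how the change would behave on any further core.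

The compounds shown do not separate the several ways in which the two cores differ, so it remains open which of those differences sets the size of the step. Also open, going by these compounds, is how the two cores would respond to other groups at this place, such as a pyridine ring carrying an amine or a carboxylic acid instead of the fluorine.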